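Cytotoxicity notes on the benzyl swap from compound 3 to compound 4

A few compounds are considered here, and "the series" means these few. Any claim that something is new, unique, unknown or untested is made for them only; others in the source may bear on it.

Within the data shown here, compound 3 `Cc1c(Cc2ccc(F)cc2)c(=O)oc2cc(OCC(O)CN3CCC(C(N)=O)CC3)ccc12` is the one member of the series with a numerical read-out in an ADME assay on A549 cells (Homo sapiens) for cytotoxicity, read by CellTiter-Glo (a lower number here means that less compound is tolerated, a higher number that more compound is tolerated), where compound 3 gives 89300 nM. Compound 1 `Cc1c(Cc2ccccc2)c(=O)oc2cc(OCC(O)CNCC3CC3)ccc12` reaches only a limit of the assay, > 100000 nM in this assay. Compound 2 `Cc1c(Cc2ccccc2)c(=O)oc2cc(OCC(O)CNc3nc4ccccc4[nH]3)ccc12` likewise sits at a limit, > 100000 nM in this assay. Among the measured compounds shown here, the single measured step, a step that the two limits leave unreadable from compound 1 to compound 2, is therefore not readable in size, and the limit of > 100000 nM in this assay, at which 2 of the 3 values shown sit, is all the evidence the series offers on that step. For the measured compounds named here, compound 4 `Cc1c(Cc2ccccc2C(F)(F)F)c(=O)oc2cc(OCC(O)CN3CCC(C(N)=O)CC3)ccc12` differs from compound 3 by 2-(trifluoromethyl)phenyl in place of 4-fluorophenyl on a saturated chain carbon bound to an aromatic carbon; no measured pair changes the group on that saturated chain carbon bound to an aromatic carbon, so no measured step bears on this change. With one number and two limits, and with nothing in the measured steps pointing either way, the expectation for compound 4 is no step beyond the scatter. The step from compound 3 to compound 4 is expected to be a 1.1-fold higher number from compound 3 to compound 4 (0.03 log units; within the scatter). Compound 4 is accordingly estimated at 95000 nM, with a range of 40000 nM to 220000 nM, and a fair chance that only a limit is returned.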

Compound 4, half-maximal cytotoxic concentration: > 100000 nM
Compound 4: a limit, no number; the forecaster's own chance of this, stated with the estimate: 55%; middle value at least 1.0-fold (0.02 log units) away from the limit.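

Among these compounds, the first readable change at this position, on a saturated chain carbon bound to an aromatic carbon, gives in this assay an at least 1.1-fold higher number from compound 3 to compound 4 (0.04 log units; that floor lies within the scatter), and that floor is all that can be said of its size. Among the compounds shown here, compound 4 gives > 100000 nM, a limit of the assay and not a number, so replacing 4-fluorobenzyl with 2-(trifluoromethyl)benzyl, with the rest of the molecule unchanged, gives no sign that less compound is tolerated. The series now rests largely on a single ceiling: the limit of > 100000 nM in this assay, at which 3 of the 4 values shown sit.

For the compounds shown here, how far compound 4 truly lies from compound 3 stays open, whether within the scatter or well beyond it, and no step between two compounds at the limit can be read. Also open, on these data alone, is how this position responds when the benzyl group carries an amine or a carboxylic acid, or when a longer chain links the aromatic ring to the core, with the side chain of compound 3 kept in place.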